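The source may hold more compounds than are shown below. What is called first, only, known or untested is meant among the compounds shown, and "the series" means these compounds.

Measured so far:
compound 1 `C[C@H]1[C@H](O[Si](c2ccccc2)(c2ccccc2)C(C)(C)C)C[C@]2(C)CC(=O)C[C@]12C` gives 14300 nM
compound 2 `C[C@@H]1[C@@H]2[C@@H](CC(=O)[C@H]2C)C[C@H]1O[Si](c1ccccc1)(c1ccccc1)C(C)(C)C` gives 14800 nM
compound 3 `C#CC(=O)O[C@H]1C[C@@H]2CC3(C[C@@H]2C1)OCC(C)(C)CO3` gives 2200 nM

All three values come from a functional assay on L929 cells (Mus musculus) for antiproliferative activity, read by MTT assay (on this read-out lower numbers stand for stronger inhibition and higher numbers for weaker inhibition), and no two of these compounds differ in one place only, so no measured step is available. Compound 2 (14800 nM) lies within the scatter of compound 1, while compound 3 gives a lower number, beyond the scatter.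

Compound 4 `C=CC[C@@H]1C(=O)C[C@H]2C[C@@H](O[Si](c3ccccc3)(c3ccccc3)C(C)(C)C)[C@H](C)[C@H]21` departs from compound 2 by one change: vinyl in place of hydrogen on a saturated chain carbon bound to a saturated ring carbon, which also reads as methyl to allyl. For the measured compounds named here, the series holds no measured example of this change, so the expectation is loose. It rests only on compound 1 (14300 nM) and compound 2 (14800 nM) sitting within the scatter of each other. The expected change, a 1.2-fold lower number from compound 2 to compound 4 (0.09 log units; within the scatter) (toward a slightly lower number), stays within the scatter. For compound 4 the estimate is 12000 nM (expected range 5000 nM to 30000 nM).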

Compound 4, half-maximal inhibitory concentration: 5100 nM
Estimate against measurement, compound 4: 2.4-fold (0.37 log units) above; the range from low to high includes it.
By their numbers in this assay, from the lowest: compound 3; then compound 4; then compounds 1 and 2 (each within the scatter of the next).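

In this assay, for the compounds shown here, vinyl in place of hydrogen on a saturated chain carbon bound to a saturated ring carbon gives a 2.9-fold lower number from compound 2 to compound 4 (0.46 log units; beyond the scatter), the only step and one that lies beyond the scatter. This shows that the number moves with a change at this position, which compound 1, compound 2 and compound 3 could not show, as no two of them differ in one place only. No measured data here account for the step.

Whether the lower number belongs to the double bond of the allyl group or to the longer chain alone stays open, as a saturated propyl chain at this place is not among the compounds shown. Also open, on these data alone, is how an amine or a carboxylic acid on this chain would read.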